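From cyclopentyloxy to methoxy: notes on compound 4

A few compounds are considered here, and "the series" means these few. Any claim that something is new, unique, unknown or untested is made for them only; others in the source may bear on it.

In a functional assay on AGS cells (Homo sapiens) for antiproliferative activity, read by MTT assay, with a stated time of 48 h (on this read-out lower numbers stand for stronger inhibition of growth and higher numbers for weaker inhibition of growth), compound 1 (`COc1ccccc1OCCNc1ccc(=O)n(Cc2ccc(OC)c(OC3CCCC3)c2)n1`) reads > 100000 nM, which is a limit and not a number. Compound 3 (`COc1ccccc1OCCNc1cnn(Cc2ccc(OC)c(OC3CCCC3)c2)c(=O)c1Cl`) reads > 100000 nM, which is also a limit. Compound 1 therefore stands at the limit of > 100000 nM in this assay, at which 2 of the 3 values shown sit, with no number of its own to serve as a starting point. Going by the values given here, compound 2 (`COc1ccccc1OCCNc1ccc(=O)n(Cc2ccc(OC(F)F)c(OC3CCCC3)c2)n1`) is the only compound here with a number, 23600 nM.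

Compound 4 (`COc1ccc(Cn2nc(NCCOc3ccccc3OC)ccc2=O)cc1OC`) has not yet been measured. It keeps the core of compound 1 and changes one group, cyclopentyloxy to methoxy: methyl in place of cyclopentyl on an oxygen on an aromatic ring. Among the compounds with values here, the only measured step bearing on it is an at least 4.2-fold lower number from compound 1 to compound 2 (0.62 log units; beyond the scatter). That step puts difluoromethyl in place of methyl on an oxygen on an aromatic ring, so it is only an indirect guide, and it involves a different group from the cyclopentyl that leaves here. Its direction also offers no support for a gain, since there a methyl leaves an oxygen, whereas here a methyl enters on one. No step beyond the scatter is expected in this assay, and the expected step is a step that the limit leaves unreadable from compound 1 to compound 4. Compound 4 is estimated at 120000 nM, with an expected range of 50000 nM to 300000 nM, and the reading will most likely be a limit again.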

Compound 4, concentration for 50% growth inhibition: > 100000 nM
Compound 4 was reported as a limit; the forecaster's own chance of this, stated with the estimate: 80%; the middle value lies beyond the limit too.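

In this assay compound 4 reads > 100000 nM, which is a limit. Compound 1 also sits at a limit, so no step can be read between compound 1 and compound 4: the limit of > 100000 nM in this assay, at which 3 of the 4 values shown sit.

The compounds shown leave open whether methyl in place of cyclopentyl on an oxygen on an aromatic ring changes growth inhibition at all, and in which direction.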